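Macrophage tolerance notes: compound 4 from compound 1

A few compounds are considered here, and "the series" means these few. Any claim that something is new, unique, unknown or untested is made for them only; others in the source may bear on it.

Readings in an ADME assay on cells (Macrophage) for cytotoxicity, read by MTT assay, with a stated time of 24 h (a higher number here means that more compound is tolerated, a lower number that less compound is tolerated), so far:
Compound 1 `O=C(/C=C/c1cccc(Br)c1)NNC(=O)c1ccc2c(c1)OCCO2` gives 351000 nM.
Compound 2 `COc1ccccc1/C=C/C(=O)NNC(=O)c1ccc2c(c1)OCCO2` gives 312000 nM.
Compound 3 `Cc1cccc(/C=C/C(=O)NNC(=O)c2ccc3c(c2)OCCO3)c1` gives 281000 nM.

Compound 1 holds the highest of the three numbers in this assay, but both other compounds lie within the scatter of it. Compound 4 `O=C(/C=C/c1ccccc1[N+](=O)[O-])NNC(=O)c1ccc2c(c1)OCCO2` differs from compound 1 in one place: 2-nitrophenyl in place of 3-bromophenyl on a double-bonded chain carbon bound to a double-bonded chain carbon. Among the measured compounds shown here, the steps that bear on this swap of the aryl group are a 1.1-fold lower number from compound 1 to compound 2 (0.05 log units; within the scatter), a 1.2-fold lower number from compound 1 to compound 3 (0.10 log units; within the scatter) and a 1.1-fold lower number from compound 2 to compound 3 (0.05 log units; within the scatter), every one within the scatter. No step beyond the scatter is therefore expected in this assay in either direction, so compound 4 is estimated at 320000 nM, between 200000 nM and 500000 nM, meaning an expected step of a 1.1-fold lower number from compound 1 to compound 4 (0.04 log units; within the scatter).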

Compound 4, half-maximal cytotoxic concentration: 257000 nM
For compound 4 the middle estimate is 1.2-fold (0.10 log units) above the measured one, within the range that was stated.
By their numbers in this assay, from the lowest: compounds 4, 3, 2 and 1 (each within the scatter of the next).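

In this assay, the 2-nitrophenyl group, with its hydrogen-bond acceptors and its double bond outside the ring, stays within the scatter of all three earlier aryl groups (a 1.4-fold lower number from compound 1 to compound 4 (0.14 log units; within the scatter); a 1.1-fold lower number from compound 3 to compound 4 (0.04 log units; within the scatter); a 1.2-fold lower number from compound 2 to compound 4 (0.08 log units; within the scatter)). On the double-bonded chain carbon, a nitro-bearing aryl group therefore joins the bromo, methoxy and methyl ones with no step beyond the scatter. No supporting data bear on these readings. Going by these compounds, whether a phenyl group carrying an amine or a carboxylic acid, or a longer chain in place of the aryl group, would give a step beyond the scatter remains open.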